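The source may hold more compounds than are shown below. What is called first, only, known or untested is meant among the compounds shown, and "the series" means these compounds.

Working notes on the series. In an assay on isolated protein for inhibition of leukotriene B4 receptor 1 (Homo sapiens), tested at 10 uM (on this read-out lower numbers stand for less inhibition and higher numbers for more inhibition at the one concentration tested (going by the name of the read-out)), compound 1 `CC(=O)c1cc(C)c(OCCCCC#N)cc1O` gives 79%, compound 2 `CCCCCCc1cc(C(C)=O)c(O)cc1OCCCCC#N` gives 51% and compound 3 `C=CCc1cc(C(C)=O)c(O)cc1OCCCCC#N` gives 92%. Compound 3 stands highest of the three, with compound 1 nearest and compound 2 furthest, both beyond the scatter. The measured steps change only the saturated chain carbon bound to the aromatic carbon: a number 28 percentage points lower from compound 1 to compound 2 (beyond the scatter), a number 13 percentage points higher from compound 1 to compound 3 (beyond the scatter) and a number 41 percentage points higher from compound 2 to compound 3 (beyond the scatter).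

Compound 4 `C=CCc1ccc(O)cc1OCCCCC#N` differs from compound 3 at another place: hydrogen in place of acetyl on an aromatic carbon. Among the compounds with values here, no measured step touches the acetyl group, so the data give no direct guide to the size or direction of this step; the three measured steps show only that the number goes lower or higher with changes on the saturated chain carbon bound to the aromatic carbon, with the hydroxy and acetyl groups held constant throughout. The step is therefore expected to be uncertain, with loss of the acetyl group estimated to lower the number modestly, a number 32 percentage points lower from compound 3 to compound 4 (beyond the scatter), but with a wide range. Compound 4 is expected to give about 60%, within 20% to 92%.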

Compound 4, a percentage reported as inhibition, at one concentration (the size of the read-out at that concentration, not a potency): 29%
For compound 4 the middle estimate is 31 percentage points above the measured one; measured number inside the range.
By their numbers in this assay, from the lowest: compound 4; then compound 2; then compound 1; then compound 3.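

With the allyl group held constant, replacing acetyl by hydrogen on the aromatic carbon ortho to a hydroxy group gives a number 63 percentage points lower from compound 3 to compound 4 (beyond the scatter) in this assay. Within the data shown here, all the earlier steps kept the acetyl group in place and varied only the saturated chain carbon, so this pair is the first sign that the read-out also depends on this second position, and that the acetyl group cannot be dropped here without a large loss. Nothing at hand accounts for the size of this step.

As far as these compounds go, this reading rests on a single pair, so it remains open whether the same loss would appear with the pentyl-bearing chain of compound 2 or the shorter substituent of compound 1. From the compounds shown here alone, it is also open how a carboxylic acid, an amine or a longer acyl chain would fare at this aromatic carbon in place of acetyl.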